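Amine substituent change from compound 3 to compound 4

The source may hold more compounds than are shown below. What is called first, only, known or untested is meant among the compounds shown, and "the series" means these compounds.

- compound 1 `COc1ccccc1NC1=CC(=O)c2c(nc3n2[C@H]2OC[C@@H](O)[C@H]2OC3)C1=O` gives 6580 nM
- compound 2 `O=C1C(N2CCCC2)=CC(=O)c2c1nc1n2[C@H]2OC[C@@H](O)[C@H]2OC1` gives > 16000 nM, which is a limit
- compound 3 `COc1ccccc1NC1=CC(=O)c2nc3n(c2C1=O)[C@H]1OC[C@@H](O)[C@H]1OC3` gives > 4000 nM, which is a limit

All three readings come from a functional assay on MCF7 cells (Homo sapiens) for inhibition, read by sulforhodamine B assay (a higher number here means a weaker inhibitor, a lower number a stronger inhibitor), and describe weak inhibitors. Compound 3 stands only at a limit, > 4000 nM, and has no number. Compound 4 `Cc1ccc(NC2=CC(=O)c3nc4n(c3C2=O)[C@H]2OC[C@@H](O)[C@H]2OC4)cc1C` differs from it as follows: 3,4-dimethylphenyl in place of 2-methoxyphenyl on an amine nitrogen. Going by the values given here, the one measured step, an at least 2.4-fold higher number from compound 1 to compound 2 (0.38 log units; beyond the scatter), swaps the aryl amine for pyrrolidin-1-yl, so it bears only loosely on an exchange of one aryl group for another. Compound 3 has the same 2-methoxyphenyl group as compound 1, which gives 6580 nM as the nearest anchor. No change beyond the scatter is expected from that anchor. The expected step is a step that the limit leaves unreadable from compound 3 to compound 4. Compound 4 is estimated at 6000 nM, within an expected range of 2500 nM to 16000 nM.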

Compound 4, half-maximal inhibitory concentration: 2080 nM
Beside the measured number, compound 4's estimate is 2.9-fold (0.46 log units) above it, and the stated range ends above it.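

In this assay, 3,4-dimethylphenyl in place of 2-methoxyphenyl on the amine nitrogen gives an at least 1.9-fold lower number from compound 3 to compound 4 (0.28 log units; that floor lies within the scatter). This position therefore accepts an aryl group without the oxygen of 2-methoxyphenyl, and the reading is a measured value rather than a limit. The true size of the step stays unfixed because compound 3 rests at a limit: the limit of > 4000 nM in this assay, at which 1 of the 4 values shown sits.

Still open, as far as these compounds go, is how a phenyl ring carrying a carboxylic acid, or a longer chain ending in an amine, would read on this nitrogen. Also open, from the compounds shown here alone, is whether a single methyl on the phenyl ring would read like compound 4.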